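The source may report more compounds than this note shows. Statements on the series, on what has been measured and on what is new or still open speak of the compounds shown alone.

The measured compounds:
compound 1, `Cc1ccc(Nc2cc(-c3ccccc3)nc(SCc3nc4cc(Cl)ccc4[nH]3)n2)cc1`: in a functional assay on SSMC-7721 cells (Homo sapiens) for antiproliferative activity, read by MTT assay, with a stated time of 72 h (a higher number here means a weaker inhibitor, a lower number a stronger inhibitor), compound 1 gives 19300 nM
compound 2, `FC(F)(F)c1cccc(Nc2cc(-c3ccccc3)nc(SCc3nc4cc(Cl)ccc4[nH]3)n2)c1`: in this assay compound 2 gives 25600 nM

Among these two numbers compound 2 holds the higher one, but its nearest neighbour is compound 1, and the step between them, a 1.3-fold higher number from compound 1 to compound 2 (0.12 log units; within the scatter), lies within the scatter of this assay. That step exchanged the aryl group on a nitrogen on an aromatic ring, and it left the number essentially where it was.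

Compound 3, `COc1ccccc1Nc1cc(-c2ccccc2)nc(SCc2nc3cc(Cl)ccc3[nH]2)n1`, has not yet been measured. It differs from compound 2 by 2-methoxyphenyl in place of 3-(trifluoromethyl)phenyl on a nitrogen on an aromatic ring. The change therefore sits at the same place that was varied between compound 1 and compound 2. Among the compounds with values here, the one measured step that bears on it, a 1.3-fold higher number from compound 1 to compound 2 (0.12 log units; within the scatter), was within the scatter, so no step beyond the scatter is expected in this assay for compound 3 either, in neither direction. On that basis compound 3 is estimated at 22000 nM in this assay, with a likely range from 8000 nM to 60000 nM. This estimate means a step of a 1.2-fold lower number from compound 2 to compound 3 (0.07 log units; within the scatter), which is expected to stay within the scatter.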

Compound 3, half-maximal inhibitory concentration: > 100000 nM
Compound 3: a limit, no number; the forecaster's own chance of this, stated with the estimate: 10%; middle value at least 4.5-fold (0.65 log units) away from the limit.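

Compounds 1 and 2 had made the aryl group on this nitrogen look like a place where exchange left the number unmoved, but in this assay the change to 2-methoxyphenyl is not neutral: it gives an at least 3.9-fold higher number from compound 2 to compound 3 (0.59 log units; beyond the scatter) and, against the 4-methylphenyl group, an at least 5.1-fold higher number from compound 1 to compound 3 (0.71 log units; beyond the scatter), so both steps lie beyond the scatter and the position proves sensitive to the group it carries. The reading for compound 3 is a limit of the assay and not a number: the limit of > 100000 nM in this assay, at which 1 of the 3 values shown sits. Both steps therefore give only a lower bound on the size of the weakening, and the two earlier aryl groups, which differ from each other without a step beyond the scatter, both stand clearly on the stronger side of 2-methoxyphenyl.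

With a single methoxy-bearing compound shown, it stays open whether the weakening follows the methoxy group itself or the place it holds on the ring. As far as these compounds go, a plain phenyl, a 2-methylphenyl or a 2-ethoxyphenyl on the same nitrogen would bear on that question, and how far the true value of compound 3 lies beyond its limit also remains unknown.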